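A few compounds are considered here, and "the series" means these few. Any claim that something is new, unique, unknown or untested is made for them only; others in the source may bear on it.

Measured compounds:
Compound 1, `CC(C)OC(=O)N1CCC(O[C@H]2CC[C@H](Oc3cnc(S(C)(=O)=O)cn3)CC2)CC1`, gives 120%.
Compound 2, `CS(=O)(=O)c1cnc(O[C@H]2CC[C@H](OC3CCN(CC4(C(F)(F)F)CC4)CC3)CC2)cn1`, gives 124%.

In a functional assay on isolated protein for agonist activity at Glucose-dependent insulinotropic receptor (Rattus norvegicus), read by HTRF and cAMP accumulation (a lower number here means a smaller maximal response, a higher number a larger maximal response), compound 2 gives 124%, and the step of a number 4 percentage points higher from compound 1 to compound 2 (within the scatter) lies within the scatter, so compound 1 and compound 2 stand level. Compound 3, `CC(F)Cc1nc(CN2CCC(O[C@H]3CC[C@H](Oc4cnc(S(C)(=O)=O)cn4)CC3)CC2)no1`, differs from compound 2 by 5-(2-fluoropropyl)-1,2,4-oxadiazol-3-yl in place of 1-(trifluoromethyl)cyclopropyl on a saturated chain carbon bound to an amine nitrogen in a ring. Among the measured compounds shown here, the only measured step also exchanged the group on the ring amine nitrogen and hardly moved the maximal response, which is the sole guide here. The expected step is a number 4 percentage points lower from compound 2 to compound 3 (within the scatter), none beyond the scatter. Compound 3 is therefore estimated at 120%, between 100% and 135%.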

Compound 3, largest response reached (Emax), in percent of the reference or control that the assay uses: 114%
The estimate for compound 3 lay 6 percentage points above the measured number; the range from low to high includes it.
By their numbers in this assay, from the lowest: compounds 3, 1 and 2 (each within the scatter of the next).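

In this assay, 5-(2-fluoropropyl)-1,2,4-oxadiazol-3-yl in place of 1-(trifluoromethyl)cyclopropyl gives a number 10 percentage points lower from compound 2 to compound 3 (within the scatter) and so shows that a five-membered aromatic ring with 3 hetero atoms stands level with a three-membered carbon ring at this place. (5-(2-fluoropropyl)-1,2,4-oxadiazol-3-yl)methyl in place of isopropoxycarbonyl on the amine nitrogen in a ring gives a number 6 percentage points lower from compound 1 to compound 3 (within the scatter) and so the three groups shown on that nitrogen all stand level. On these data alone, whether a carboxylic acid or a simple amine on this chain carbon would also hold the maximal response remains open. No further measurement bears on this result.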